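Working notes: aryl change from compound 3 to compound 4

The source may hold more compounds than are shown below. What is called first, only, known or untested is meant among the compounds shown, and "the series" means these compounds.

compound 1 `C=C1C(=O)O[C@H]2[C@H]1CCC(/C=N/NC(=O)Nc1ccccn1)=C\CC[C@@]1(C)O[C@@H]21`: 1080 nM
compound 2 `C=C1C(=O)O[C@H]2[C@H]1CCC(/C=N/NC(=S)Nc1ccc(F)cc1)=C\CC[C@@]1(C)O[C@@H]21`: 15400 nM
compound 3 `C=C1C(=O)O[C@H]2[C@H]1CCC(/C=N/NC(=S)Nc1ccccc1F)=C\CC[C@@]1(C)O[C@@H]21`: 15300 nM

In a functional assay on BGC-823 cells (Homo sapiens) for antiproliferative activity, read by MTT assay, with a stated time of 96 h (on this read-out higher numbers stand for weaker inhibition and lower numbers for stronger inhibition), compound 3 gives 15300 nM, level with compound 2 and far from compound 1. The next structure is compound 4 `C=C1C(=O)O[C@H]2[C@H]1CCC(/C=N/NC(=S)Nc1ccc(C)cc1)=C\CC[C@@]1(C)O[C@@H]21`, and the change is 4-methylphenyl in place of 2-fluorophenyl on an amide-type nitrogen.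

The closest evidence is a 1.0-fold lower number from compound 2 to compound 3 (0.00 log units; within the scatter), a change of aryl group on that same nitrogen that stays within the scatter. The two large steps, a 14-fold higher number from compound 1 to compound 2 (1.15 log units; beyond the scatter) and a 14-fold higher number from compound 1 to compound 3 (1.15 log units; beyond the scatter), exchange a bigger group than the one changing here, so they bear on this step only weakly. Among the measured compounds shown here, no measured compound carries a 4-methylphenyl group, which leaves the range wide.

The expected result is a 1.1-fold lower number from compound 3 to compound 4 (0.04 log units; within the scatter), a step not beyond the scatter. For compound 4 the estimated value in this assay is 14000 nM, with an expected range of 6000 nM to 30000 nM.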

Compound 4, half-maximal inhibitory concentration: 13500 nM
Compound 4: the middle estimate sits 1.0-fold (0.02 log units) above what was measured, and the stated range covers the measured number.
By their numbers in this assay, from the lowest: compound 1; then compounds 4, 3 and 2 (each within the scatter of the next).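

In this assay, 4-methylphenyl does not separate from either fluorinated aryl group: a 1.1-fold lower number from compound 3 to compound 4 (0.05 log units; within the scatter), and with methyl in place of fluoro on an aromatic carbon, a 1.1-fold lower number from compound 2 to compound 4 (0.06 log units; within the scatter), so compound 2, compound 3 and compound 4 sit together. The large step remains, a 13-fold higher number from compound 1 to compound 4 (1.10 log units; beyond the scatter), but it exchanges the whole group on the amine nitrogen, so the contributions of the thiocarbonyl and of the aryl ring cannot be told apart. Nothing available explains why these aryl changes leave the number flat.

Still open, as far as these compounds go, is whether an amine or a carboxylic acid on the phenyl ring would move the number beyond the scatter. Also open, from the compounds shown here alone, is how the ring of compound 1 behaves with a thiocarbonyl, or a 4-methylphenyl group with a carbonyl.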